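Carrying the Methoxypyridine Amide Step onto Compound 3

A few compounds are considered here, and "the series" means these few. Any claim that something is new, unique, unknown or untested is made for them only; others in the source may bear on it.

Compound 1, `COc1cc(N(C)CCN(C)C)c(NC(=O)c2ccnc(Cl)c2)cc1Nc1nccc(-c2cn(C)c3ccccc23)n1`, gives 2050 nM in a functional assay on NCI-H1975 cells (Homo sapiens) for antiproliferative activity, read by MTT assay, with a stated time of 72 h; a lower number here means a stronger inhibitor, a higher number a weaker inhibitor.
Compound 2, `COc1cc(N(C)CCN(C)C)c(NC(=O)c2ccncc2OC)cc1Nc1nccc(-c2cn(C)c3ccccc23)n1`, gives 1010 nM in this assay.
Compound 3, `COc1cc(N(C)CCN(C)C)c(NC(=O)c2ccnc(Cl)c2)cc1Nc1nccc(-c2cn(CCCO)c3ccccc23)n1`, gives 1820 nM in this assay.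

Within the data shown here, compound 3 stands second highest of the three numbers; the one step measured onto it is a 1.1-fold lower number from compound 1 to compound 3 (0.05 log units; within the scatter), and the number of compound 3 lies within the scatter of that of compound 2 as well. Compound 4, `COc1cc(N(C)CCN(C)C)c(NC(=O)c2ccncc2OC)cc1Nc1nccc(-c2cn(CCCO)c3ccccc23)n1`, differs from compound 3 by 3-methoxypyridin-4-yl in place of 2-chloropyridin-4-yl on a carbonyl carbon. The same change has been measured once, as a 2.0-fold lower number from compound 1 to compound 2 (0.31 log units; beyond the scatter), a modest lowering on the shared core. The step from compound 3 to compound 4 is therefore expected to be a 1.9-fold lower number from compound 3 to compound 4 (0.28 log units; within the scatter) in this assay. Compound 4 is accordingly estimated at 950 nM, within a range from 450 nM to 2000 nM.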

Compound 4, half-maximal inhibitory concentration: 1970 nM
Estimate against measurement, compound 4: 2.1-fold (0.32 log units) below, within the range that was stated.
By their numbers in this assay, from the lowest: compounds 2, 3, 4 and 1 (each within the scatter of the next, the first and the last beyond it).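

On the core of compound 3, 3-methoxypyridin-4-yl in place of 2-chloropyridin-4-yl on a carbonyl carbon gives a 1.1-fold higher number from compound 3 to compound 4 (0.03 log units; within the scatter) in this assay and stays within the scatter, so the modest lowering on the core of compound 1 does not carry over clearly. Even so, the two readings of this change cannot be told apart: the same change on two cores in this assay, a 2.0-fold lower number (0.31 log units; beyond the scatter) from compound 1 to compound 2 and a 1.1-fold higher number (0.03 log units; within the scatter) from compound 3 to compound 4, 2.2-fold (0.34 log units) apart, within the scatter of two such steps. The 2-hydroxyethyl change, now read as a 2.0-fold higher number from compound 2 to compound 4 (0.29 log units; within the scatter) on the methoxypyridine amide, likewise stays unresolved: the same change on two cores in this assay, a 1.1-fold lower number (0.05 log units; within the scatter) from compound 1 to compound 3 and a 2.0-fold higher number (0.29 log units; within the scatter) from compound 2 to compound 4, 2.2-fold (0.34 log units) apart, within the scatter of two such steps. From the compounds shown here alone, whether an amine, a carboxylic acid or a longer chain in place of that 2-hydroxyethyl would shift these numbers remains open.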